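The compounds below may be only part of what the source reports. "The series", "measured", "known", "first", "only" and "open" are said of these compounds alone.

In a functional assay on RKO cells (Homo sapiens) for inhibition, read by MTT assay, with a stated time of 48 h (a lower number here means a stronger inhibitor, a higher number a weaker inhibitor), compound 1 `COc1ccc(N(C)c2nc(C)nc3ccccc23)cc1C(=O)OCCCC[Se]C#N` gives 1020 nM. That lies within the scatter of compound 2 `COc1ccc(N(C)c2nc(C)nc3ccccc23)cc1C(=O)OCCCCCC[Se]C#N` at 1990 nM. Compound 3 `COc1ccc(N(C)c2nc(C)nc3ccccc23)cc1C(=O)OCCCCC[Se]C#N`, at 356 nM, is the strongest of the three, with a 2.9-fold lower number from compound 1 to compound 3 (0.46 log units; beyond the scatter) and a 5.6-fold lower number from compound 2 to compound 3 (0.75 log units; beyond the scatter). These compounds differ only in the length of a saturated chain, and the remaining step is a 2.0-fold higher number from compound 1 to compound 2 (0.29 log units; within the scatter). Compound 4 `COc1ccc(N(C)c2nc(C)nc3ccccc23)cc1OCCCCC[Se]C#N` brings a different change: a group of 9 heavy atoms (6 carbon, 1 nitrogen, 1 oxygen, 1 selenium; no ring) in place of a group of 10 heavy atoms (6 carbon, 1 nitrogen, 2 oxygen, 1 selenium; no ring), on an aromatic carbon. Going by the values given here, no measured pair isolates this swap, so only these chain steps bear on it, and they offer a rough guide to size, not a firm direction. A small shift toward a lower number is expected, within the scatter: a 1.6-fold lower number from compound 1 to compound 4 (0.20 log units; within the scatter). For compound 4 the estimated value is 650 nM, with an expected range of 180 nM to 2300 nM.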

Compound 4, half-maximal inhibitory concentration: 3560 nM
Beside the measured number, compound 4's estimate is 5.5-fold (0.74 log units) below it, outside the stated range (above it).
By their numbers in this assay, from the lowest: compound 3; then compounds 1, 2 and 4 (each within the scatter of the next, the first and the last beyond it).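

Swapping the group on this aromatic carbon, ortho to a methoxy group, for one without the carbonyl gives a 3.5-fold higher number from compound 1 to compound 4 (0.54 log units; beyond the scatter) in this assay, so this link affects the number beyond the scatter. With the same chain as compound 4 and the carbonyl kept, compound 3 gives 356 nM, whereas compound 4 gives 3560 nM. Nothing available explains why the number rises here. Still open, going by these compounds, is how an amide link at this position would compare, and whether a shorter or longer chain would change the number for compound 4.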